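The source may hold more compounds than are shown below. What is called first, only, known or untested is meant among the compounds shown, and "the series" means these compounds.

Measured so far in a functional assay on cells for agonist activity at Free fatty acid receptor 1 (Homo sapiens), read by FLIPR and calcium flux, with a stated time of 100 s; on this read-out lower numbers stand for an effect already at smaller amounts and higher numbers for an effect only at larger amounts of compound: compound 1 `O=C(O)C[C@@H]1CCCN1c1ccc(Oc2ccc(Cl)cc2Cl)cc1`, 360 nM; compound 2 `O=C(O)C[C@@H]1CCCN1c1ccc(Oc2ccccc2F)cc1`, 150 nM; compound 3 `Cc1ccc(Oc2ccc(N3CCC[C@H]3CC(=O)O)cc2)cc1`, 490 nM.

Compound 3 is set apart from compound 2 by a 3.3-fold higher number from compound 2 to compound 3 (0.51 log units; beyond the scatter), while a 1.4-fold higher number from compound 1 to compound 3 (0.13 log units; within the scatter) separates it from compound 1. Compound 4 `O=C(O)C[C@@H]1CCCN1c1ccc(Oc2ccc(Cl)cc2)cc1` differs from compound 3 by chloro in place of methyl on an aromatic carbon. The step that bears most on this is a 1.4-fold higher number from compound 1 to compound 3 (0.13 log units; within the scatter), since compound 1 already carries chloro at that same place as part of its 2,4-dichlorophenyl and sits within the scatter of compound 3. The step of a 2.4-fold lower number from compound 1 to compound 2 (0.38 log units; beyond the scatter) concerns another part of the ring and offers no further guide. Compound 4 is therefore expected to show a 1.2-fold lower number from compound 3 to compound 4 (0.09 log units; within the scatter), no change beyond the scatter. The estimated value of compound 4 is 400 nM, between 200 nM and 800 nM.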

Compound 4, half-maximal effective concentration: 290 nM
The estimate for compound 4 lay 1.4-fold (0.14 log units) above the measured number, and the stated range covers the measured number.
By their numbers in this assay, from the lowest: compounds 2, 4, 1 and 3 (each within the scatter of the next, the first and the last beyond it).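

In this assay, chloro in place of methyl on this aromatic carbon, para to a large group, stays within the scatter (a 1.7-fold lower number from compound 3 to compound 4 (0.23 log units; within the scatter)), so the two groups are not told apart here. The 4-chlorophenyl of compound 4 is also not told apart from the 2,4-dichlorophenyl (a 1.2-fold lower number from compound 1 to compound 4 (0.09 log units; within the scatter)) or from the 2-fluorophenyl (a 1.9-fold higher number from compound 2 to compound 4 (0.29 log units; within the scatter)), even though compound 2 and compound 3 lie beyond the scatter of each other. Nothing available explains these steps. As far as these compounds go, whether methoxy, trifluoromethyl or a nitrile at this place would shift the number beyond the scatter remains open.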